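This account rests on a few compounds, and the source may have more. Where it says the series, first, only, none or still open, it means among the compounds named here.

Measured in an assay on membranes from HeLa cells for displacement of a labelled ligand from adenosine receptor A3 (Homo sapiens), read by scintillation counting, with a stated time of 180 min, tested at 1 uM; on this read-out higher numbers stand for more inhibition at the one concentration tested (going by the name of the read-out) and lower numbers for less inhibition:

compound 1 `CC1=C(C(=O)NC(C)C)C(c2ccco2)NC(=O)N1` gives 4%
compound 2 `CCC(CC)OC(=O)C1=C(C)NC(=O)NC1c1ccco1` gives 1%
compound 3 `CC1=C(C(=O)OC2CCC2)C(c2ccco2)NC(=O)N1` gives 1%

Compound 3 stands level with compound 2 at the digits shown, and compound 1 sits within the scatter of both: a number 3 percentage points lower from compound 1 to compound 3 (within the scatter), a number 3 percentage points lower from compound 1 to compound 2 (within the scatter). Within the data shown here, none of the three numbers is separated from another by more than the usual scatter, so the series so far reads as flat in this assay.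

Compound 4 `CC1=C(C(=O)OCC2CC2)C(c2ccco2)NC(=O)N1` is unmeasured. It differs from compound 3 only at the ester side: cyclopropylmethyl in place of cyclobutyl on an oxygen next to a carbonyl group. Among the measured compounds shown here, the one measured step at this same oxygen is no change at the digits printed from compound 2 to compound 3 (within the scatter), which shows that exchanging one four-carbon group for another at this position left the read-out unchanged. The other two steps, a number 3 percentage points lower from compound 1 to compound 2 (within the scatter) and a number 3 percentage points lower from compound 1 to compound 3 (within the scatter), alter the carbonyl substituent more deeply and still stay within the scatter. For the measured compounds named here, nothing among the measured compounds points to a change beyond the scatter for this rearrangement of the same atoms, so the expected step is no change at the digits printed from compound 3 to compound 4 (within the scatter), that is, none beyond the scatter. Compound 4 is therefore estimated at 1% in this assay, with a range of -8% to 10%.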

Compound 4, a percentage reported as inhibition, at one concentration (the size of the read-out at that concentration, not a potency): 1%
The estimate for compound 4 equals the measured number at the digits printed; the range from low to high includes it.
By their numbers in this assay, from the lowest: compounds 2, 3, 4 and 1 (each within the scatter of the next).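

Cyclopropylmethyl in place of cyclobutyl on an oxygen next to a carbonyl group keeps the count of 4 heavy atoms but exchanges a four-membered ring for a three-membered one, and in this assay this gives no change at the digits printed from compound 3 to compound 4 (within the scatter), so this ring change at this position does not separate the two esters. Two further exchanges also stay within the scatter: cyclopropylmethyl in place of pentan-3-yl gives no change at the digits printed from compound 2 to compound 4 (within the scatter), and cyclopropylmethoxy in place of isopropylamino on a carbonyl carbon gives a number 3 percentage points lower from compound 1 to compound 4 (within the scatter). Three different groups on this oxygen now read alike, but no measurement at hand explains the flat reading.

Left open is whether any group on this oxygen can move the read-out beyond the scatter, for instance a benzyl group, a longer chain or a chain ending in an amine. Also open, on these data alone, are the effect of a phenyl ring in place of the ring shared by all four compounds and whether these compounds would separate at another concentration.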